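A few compounds are considered here, and "the series" means these few. Any claim that something is new, unique, unknown or untested is made for them only; others in the source may bear on it.

For the measured compounds named here, compound 2 `COc1ccccc1NC(=S)NC1CC(C)(C)Oc2ccc(Br)cc21` is one of three compounds measured in a functional assay on U-373MG ATCC cells (Homo sapiens) for inhibition, read by MTT assay, with a stated time of 72 h (on this read-out higher numbers stand for weaker inhibition and lower numbers for stronger inhibition), where compound 2 gives 22000 nM. Compound 3 `CC1(C)CC(NC(=O)Nc2cccc(Cl)c2)c2cc(Cl)ccc2O1` gives 21000 nM and compound 1 `CC1(C)CC(NC(=O)Nc2ccccc2)c2cc(Cl)ccc2O1` gives 68000 nM; the two values of compound 2 and compound 3 lie within the scatter of each other, while compound 1 stands clearly higher. Going by the values given here, the one step measured so far, a 3.2-fold lower number from compound 1 to compound 3 (0.51 log units; beyond the scatter), concerns a substituent on an aromatic ring and does not bear directly on the present change. Compound 4 `CC1(C)CC(NC(=S)NCc2ccccc2)c2cc(Br)ccc2O1` differs from compound 2 by benzyl in place of 2-methoxyphenyl on an amide-type nitrogen. Among the compounds with values here, with no comparable step measured, the expected change in this assay is none beyond the scatter, so compound 4 is estimated at 25000 nM (range 8000 nM to 80000 nM), a step of a 1.1-fold higher number from compound 2 to compound 4 (0.06 log units; within the scatter).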

Compound 4, half-maximal inhibitory concentration: 29000 nM
For compound 4 the middle estimate is 1.2-fold (0.06 log units) below the measured one, within the range that was stated.
By their numbers in this assay, from the lowest: compounds 3, 2 and 4 (each within the scatter of the next); then compound 1.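

In this assay, the first step read at the amide-type nitrogen, a 1.3-fold higher number from compound 2 to compound 4 (0.12 log units; within the scatter), lies within the scatter, so benzyl and 2-methoxyphenyl are not told apart there. The change removes the oxygen and the hydrogen-bond acceptor counted in 2-methoxyphenyl, yet the two compounds remain inseparable in this read-out. Nothing measured here offers an explanation for this result. Going by these compounds, whether an amine, a carboxylic acid or a longer chain on this nitrogen would shift the number beyond the scatter remains open. So does whether the step would hold with a carbonyl in place of the thiocarbonyl.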